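A Methyl Added to the Shared Core of Compound 1

A few compounds are considered here, and "the series" means these few. Any claim that something is new, unique, unknown or untested is made for them only; others in the source may bear on it.

Measured in a functional assay on A-375 cells (Homo sapiens) for cytotoxicity, read by MTT assay, with a stated time of 72 h, tested at 3 uM; on this read-out lower numbers stand for less inhibition of growth and higher numbers for more inhibition of growth at the one concentration tested:
compound 1 `N/C(=N\NC(=S)N1CCCCCC1)c1ccccn1` gives 78.6%
compound 2 `Cc1cccc(/C(N)=N/NC(=S)N2CCSCC2)n1` gives 60.1%
compound 3 `Cc1ccnc(/C(N)=N/NC(=S)N2CCCCCC2)c1` gives 70%

Compound 1 has the highest of these three numbers. Nearest to it is compound 3, and the step of a number 8.6 percentage points lower from compound 1 to compound 3 (within the scatter) stays within the scatter. Furthest is compound 2, whose number lies beyond the scatter below that of compound 1; the two compounds differ in more than one place, so the values alone are all that can be said of that pair.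

Compound 4 `Cc1cccc(/C(N)=N/NC(=S)N2CCCCCC2)n1` differs from compound 1 in one place: methyl in place of hydrogen on an aromatic carbon. Going by the values given here, the one measured step that bears on this is the methyl added elsewhere on the same ring, from compound 1 to compound 3, which fell within the scatter. A methyl added to this core has so far produced no change worth the name, so compound 4 is expected to sit close to compound 1, with a number 5.6 percentage points lower from compound 1 to compound 4 (within the scatter) as the expected step. The estimate for compound 4 in this assay is 73%, within a range from 58% to 85%.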

Compound 4, percent growth inhibition at one concentration: 64.5%
Estimate against measurement, compound 4: 8.5 percentage points above; the range from low to high includes it.
By their numbers in this assay, from the lowest: compounds 2, 4, 3 and 1 (each within the scatter of the next, the first and the last beyond it).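

In this assay, methyl in place of hydrogen next to the ring nitrogen brings a modest loss of growth inhibition, a number 14.1 percentage points lower from compound 1 to compound 4 (beyond the scatter), and this is the first single change shown whose step clears the scatter. The same swap at the other place shown on the ring, a number 8.6 percentage points lower from compound 1 to compound 3 (within the scatter), did not clear it, yet compound 3 at 70% and compound 4 at 64.5% lie within the scatter of each other, so these numbers cannot firmly separate the two places. No measurement shown here accounts for the step.

On these data alone, whether a larger group at this place, such as ethyl or methoxy, takes the number further down, or an amine or a chlorine atom there behaves like methyl, stays open. Every number here also comes from a single concentration, and how the step looks across a range of concentrations is open too.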